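The source may report more compounds than this note shows. Statements on the series, on what has been measured and on what is new or still open speak of the compounds shown alone.

In a functional assay (aorta) with Rattus norvegicus as the target (on this read-out lower numbers stand for stronger inhibition and higher numbers for weaker inhibition), compound 1 `CCO/C(O)=C1\C(COCCNC(=O)NC)=NC(C)=C(C(=O)OC)C1c1ccccc1Cl` gives 3.16 nM, while compound 2 `CCO/C(O)=C1\C(COCC/N=C(\NC#N)NCCN(C)C)=NC(C)=C(C(=O)OC)C1c1ccccc1Cl` gives 50.1 nM, the higher of the two numbers recorded so far. Among the compounds with values here, the single measured step, a 16-fold higher number from compound 1 to compound 2 (1.20 log units; beyond the scatter), bears directly on the present change, since both concern the same chain position. Compound 3 `CCO/C(O)=C1\C(COCCNC(C)C(N)=O)=NC(C)=C(C(=O)OC)C1c1ccccc1Cl` differs from compound 2 as follows: a group of 6 heavy atoms (3 carbon, 2 nitrogen, 1 oxygen; no ring) in place of a group of 11 heavy atoms (6 carbon, 5 nitrogen; no ring), on a saturated chain carbon, two bonds along the chain from an oxygen on a saturated carbon. The entering group is closer in count to the group carried by compound 1, which gives 3.16 nM, than to that of compound 2. A partial reversal of the earlier step is therefore expected. For compound 3 the expected step is a 7.2-fold lower number from compound 2 to compound 3 (0.85 log units; beyond the scatter). Compound 3 is estimated at 7 nM, with a range of 2 nM to 25 nM.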

Compound 3, half-maximal inhibitory concentration: 10 nM
Compound 3: middle estimate off by 1.4-fold (0.15 log units), on the low side; the measured number falls inside the stated range.
By their numbers in this assay, from the lowest: compound 1; then compound 3; then compound 2.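

In this assay, (1-carbamoylethyl)amino at this chain carbon regains much of what the larger group of compound 2 gave up, with a 5.0-fold lower number from compound 2 to compound 3 (0.70 log units; beyond the scatter). It does not match compound 1, with a 3.2-fold higher number from compound 1 to compound 3 (0.50 log units; beyond the scatter), so the position separates 1-carbamoylethyl from methylcarbamoyl on the amine nitrogen, not only the largest group from the two smaller ones. Nothing available accounts for either step.

Open, from the compounds shown here alone, is whether the unsubstituted amine, or a carboxylic acid in place of the primary amide, would fall nearer compound 1 or compound 3. Also open, going by these compounds, is what carbamoylmethyl, lacking the branching methyl, or a longer chain on the nitrogen would give.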